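Methyl on the distal phenyl: compound 4 in the series

The source may hold more compounds than are shown below. What is called first, only, known or untested is meant among the compounds shown, and "the series" means these compounds.

Three compounds share one core. Compound 1 `CS(=O)(=O)c1ccc(-c2cnc3[nH]cc(-c4nnc(-c5ccc(F)cc5)o4)c(=O)c3c2)cc1` gives 3.11% in a functional assay on A549 cells (Homo sapiens) for inhibition, read by MTT assay, with a stated time of 24 h, tested at 5 uM; a lower number here means less inhibition of growth, a higher number more inhibition of growth at the concentration tested; compound 2 `CS(=O)(=O)c1ccc(-c2cnc3[nH]cc(-c4nnc(-c5ccccc5)o4)c(=O)c3c2)cc1` gives 8.17%; compound 3 `O=c1c(-c2nnc(-c3ccc(Cl)cc3)o2)c[nH]c2ncc(-c3ccccc3)cc12` gives 1.44%. By the bare numbers compound 2 is the highest of the three, but its gaps to compound 1 and to compound 3 both lie within the scatter, so no order can be read. Among the compounds with values here, the one single-point step, a number 5.1 percentage points higher from compound 1 to compound 2 (within the scatter), is also within the scatter. Compound 4 `Cc1cccc(-c2nnc(-c3c[nH]c4ncc(-c5ccc(S(C)(=O)=O)cc5)cc4c3=O)o2)c1` differs from compound 2 by methyl in place of hydrogen on an aromatic carbon. Within the data shown here, no measured step bears directly on this change; the only measured step lay within the scatter, and all three numbers sit low. Hence no step beyond the scatter is expected in this assay: a number 0.2 percentage points lower from compound 2 to compound 4 (within the scatter). Compound 4 is estimated at 8%, range -2% to 18%.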

Compound 4, percent growth inhibition at one concentration: 7.92%
The estimate for compound 4 lay 0.1 percentage points above the measured number; measured number inside the range.
By their numbers in this assay, from the lowest: compounds 3, 1, 4 and 2 (each within the scatter of the next).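

The earlier compounds shown here carried no group at this place on the phenyl ring, and in this assay methyl here gives a number 0.3 percentage points lower from compound 2 to compound 4 (within the scatter), so it cannot be told apart from hydrogen. The wider swap of 3-methylphenyl for 4-fluorophenyl gives a number 4.8 percentage points higher from compound 1 to compound 4 (within the scatter), and this step cannot be read either. No measurement at hand bears on this result.

Open, on these data alone, is whether a larger group at this place, such as an amine, a carboxylic acid or a longer chain, would give a step beyond the scatter. Also open, as far as these compounds go, is whether any change to the shared core lifts the number clear of the low values seen so far.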